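Swapping a Sulfanyl Pyridine for a Methylthiazole

A few compounds are considered here, and "the series" means these few. Any claim that something is new, unique, unknown or untested is made for them only; others in the source may bear on it.

Of the compounds shown here, three have been measured in a functional assay on SMMC-7721 cells (Homo sapiens) for antiproliferative activity, read by MTT assay, with a stated time of 72 h; a lower number here means a stronger inhibitor, a higher number a weaker inhibitor. Compound 1 (`C#CCSc1nc(Sc2nnnn2CCN(C)C)c(C#N)c(-c2ccc(Cl)cc2)n1`) gives 7340 nM, and compound 3 (`C=CC(=O)Nc1ccccc1CN(C(=O)Nc1cccc(C(F)(F)F)c1)C1CCN(C(C)CCC)CC1`), which has a different structure, gives 16200 nM. Compound 2 (`C#CCSc1nc(Sc2ccccn2)c(C#N)c(-c2cc(OC)c(OC)c(OC)c2)n1`) gives > 20000 nM. This is a limit of the assay and not a number, so compound 2 has no exact place among the three.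

Compound 4 (`C#CCSc1nc(Sc2nc(C)cs2)c(C#N)c(-c2cc(OC)c(OC)c(OC)c2)n1`) has not yet been measured. It has 4-methyl-1,3-thiazol-2-yl in place of pyridin-2-yl on a sulfur, and the rest of compound 2 is unchanged: 4-methyl-1,3-thiazol-2-yl in place of pyridin-2-yl on a sulfur. Going by the values given here, no measured pair in this small set shows a swap of this kind, so there is no direct precedent for its effect in this assay.

The expectation leans on a measured relative sharing much of the same core, compound 1 at 7340 nM, which shows that this family can give a number in this assay. Only a small step toward stronger inhibition is expected, and it may not exceed the usual scatter. That step is estimated as an at least 1.3-fold lower number from compound 2 to compound 4 (0.12 log units; that floor lies within the scatter). The assay may again report only a limit. Compound 4 is expected at about 15000 nM, with an estimated range of 6000 nM to 35000 nM.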

Compound 4, half-maximal inhibitory concentration: > 20000 nM
Compound 4: no number, only a limit; the forecaster's own chance of this, stated with the estimate: 50%; middle value at least 1.3-fold (0.12 log units) away from the limit.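

In this assay, going by these compounds alone, compound 4 gives only a limit, as compound 2 does, so no step between the two can be read, because both rest on the same limit of the assay: the limit of > 20000 nM in this assay, at which 2 of the 4 values shown sit. The compounds shown leave open whether 4-methyl-1,3-thiazol-2-yl in place of pyridin-2-yl on a sulfur changes inhibition at all, and in which direction.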